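Fluoro for hydroxy on the aryl ester of compound 1

This account rests on a few compounds, and the source may have more. Where it says the series, first, only, none or still open, it means among the compounds named here.

Compound 1 `C/C=C1/[C@H](O[C@@H]2O[C@H](CO)[C@@H](O)[C@H](O)[C@H]2O)OC=C(C(=O)OC)[C@H]1CC(=O)OCCc1ccc(O)cc1` is the 2-(4-hydroxyphenyl)ethyl ester of the shared core. In a functional assay on SK-BR-3 cells (Homo sapiens) for antiproliferative activity, read by MTT assay, with a stated time of 72 h (on this read-out higher numbers stand for weaker inhibition and lower numbers for stronger inhibition), compound 1 gives only a limit, > 20000 nM. Compound 2 `C/C=C1/[C@H](O[C@@H]2O[C@H](COC(C)=O)[C@@H](OC(C)=O)[C@H](OC(C)=O)[C@H]2OC(C)=O)OC=C(C(=O)OC)[C@H]1CC(=O)O` differs in several places from the first compound; in this assay compound 2 also gives a limit, > 15000 nM. Compound 3 `C/C=C1/[C@H](O[C@@H]2O[C@H](COC(C)=O)[C@@H](OC(C)=O)[C@H](OC(C)=O)[C@H]2OC(C)=O)OC=C(C(=O)OC)[C@H]1CC(=O)OCCC1CCCCC1` gives a limit too in this assay, > 15000 nM. Among the measured compounds shown here, the only single-point step measured, a step that the two limits leave unreadable from compound 2 to compound 3, is therefore not readable. Compound 4 `C/C=C1/[C@H](O[C@@H]2O[C@H](CO)[C@@H](O)[C@H](O)[C@H]2O)OC=C(C(=O)OC)[C@H]1CC(=O)OCCc1ccc(F)cc1` differs from compound 1 by fluoro in place of hydroxy on an aromatic carbon. For the measured compounds named here, no measured step bears on this change, and all values sit at limits (the limit of > 15000 nM in this assay, at which 2 of the 3 values shown sit, (the limit of > 20000 nM in this assay, at which 1 of the 3 values shown sits)). The expected step, a number no higher from compound 1 to compound 4 (the limit leaves the size open), is none beyond the scatter. Compound 4 is estimated at 20000 nM, between 8000 nM and 50000 nM.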

Compound 4, half-maximal inhibitory concentration: > 20000 nM
Compound 4 ended at the assay's limit (the forecaster's own chance of this, stated with the estimate: 75%); the middle value sits exactly at the limit.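

Compound 1 and compound 4 both stop at the same limit, so no step between them can be read: the limit of > 20000 nM in this assay, at which 2 of the 4 values shown sit.

The compounds shown leave open how hydroxy and fluoro on this aryl ester compare in this assay.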